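Aryl amine variation on the sulfonamide-linked quinazoline series

The source may report more compounds than this note shows. Statements on the series, on what has been measured and on what is new or still open speak of the compounds shown alone.

Three compounds share one core and differ only in the aryl group on the nitrogen on an aromatic ring: compound 1 `COc1cc2ncnc(Nc3ccc(F)c(Cl)c3)c2cc1OCCCCC(=O)Nc1ccc(S(N)(=O)=O)cc1`, compound 2 `COc1cc2ncnc(Nc3cccc(Br)c3)c2cc1OCCCCC(=O)Nc1ccc(S(N)(=O)=O)cc1` and compound 3 `COc1cc2ncnc(Nc3ccc(F)cc3)c2cc1OCCCCC(=O)Nc1ccc(S(N)(=O)=O)cc1`. In a functional assay on A-431 cells (Homo sapiens) for antiproliferative activity, read by MTT assay, with a stated time of 72 h (a lower number here means a stronger inhibitor, a higher number a weaker inhibitor), compound 1 gives 5020 nM. Compound 2 gives 9750 nM. Compound 3 gives 18600 nM, the highest of the three numbers; the two steps that end at it are a 1.9-fold higher number from compound 2 to compound 3 (0.28 log units; within the scatter) and a 3.7-fold higher number from compound 1 to compound 3 (0.57 log units; beyond the scatter).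

Compound 4 `COc1ccc(Nc2ncnc3cc(OC)c(OCCCCC(=O)Nc4ccc(S(N)(=O)=O)cc4)cc23)cc1OC` carries the change (3,4-dimethoxyphenyl in place of 4-fluorophenyl on a nitrogen on an aromatic ring). Among the measured compounds shown here, the steps that bear on this position are a 1.9-fold higher number from compound 1 to compound 2 (0.29 log units; within the scatter), a 1.9-fold higher number from compound 2 to compound 3 (0.28 log units; within the scatter) and a 3.7-fold higher number from compound 1 to compound 3 (0.57 log units; beyond the scatter): swapping one halogenated aryl group for another moves the number little, and dropping the chloro atom moves it modestly upward. For the measured compounds named here, no measured step brings in an aryl group without halogen or with methoxy groups, so the direction of this step rests on thin ground. The expected step from compound 3 is a 1.3-fold higher number from compound 3 to compound 4 (0.13 log units; within the scatter), leaning upward but not clearly beyond the scatter. Compound 4 is therefore estimated at 25000 nM in this assay, with a range from 8000 nM to 80000 nM.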

Compound 4, half-maximal inhibitory concentration: 35400 nM
For compound 4 the middle estimate is 1.4-fold (0.15 log units) below the measured one, within the range that was stated.
By their numbers in this assay, from the lowest: compounds 1, 2, 3 and 4 (each within the scatter of the next, the first and the last beyond it).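

In this assay, among the compounds shown here, the 3,4-dimethoxyphenyl group, the only aryl group here without halogen, gives a 1.9-fold higher number from compound 3 to compound 4 (0.28 log units; within the scatter) and so cannot be told apart from 4-fluorophenyl at this position. The same group does separate from the two aryl groups carrying a halogen on the other ring position, with a 3.6-fold higher number from compound 2 to compound 4 (0.56 log units; beyond the scatter) against 3-bromophenyl and a 7.1-fold higher number from compound 1 to compound 4 (0.85 log units; beyond the scatter) against 3-chloro-4-fluorophenyl, the widest step among the four compounds. Replacing halogen with methoxy groups on the aryl amine therefore gives no gain over any of the three halogenated groups, and the 3-chloro-4-fluorophenyl group of compound 1 keeps the lowest number, 5020 nM in this series, with compound 4 beyond the scatter from it while compound 3 is not separated from compound 4.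

Nothing at hand accounts for these steps. Still open, as far as these compounds go, is how an aryl group with a single methoxy group, a dimethylamino group or a carboxylic acid would sit relative to these four, and whether any group at this position can bring the number below that of compound 1.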